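One hydroxy group fewer on compound 2

The compounds below may be only part of what the source reports. "The series", "measured", "known", "first", "only" and "open" are said of these compounds alone.

Compound 1 `COc1cc2ncnc(Nc3ccc(F)c(Cl)c3)c2cc1NC(=O)N/N=C/c1cccc(Cl)c1Cl` gives 26100 nM in a functional assay on HepG2 cells (Homo sapiens) for cytotoxicity, read by MTT assay, with a stated time of 72 h; on this read-out higher numbers stand for weaker inhibition and lower numbers for stronger inhibition
Compound 2 `COc1cc2ncnc(Nc3ccc(F)c(Cl)c3)c2cc1NC(=O)N/N=C/c1ccc(O)cc1O` gives 32100 nM in this assay

Within the data shown here, on these numbers, compound 2 cannot be told apart from compound 1 in this assay because a 1.2-fold higher number from compound 1 to compound 2 (0.09 log units; within the scatter) is the only measured step. In that step, 2,4-dihydroxyphenyl takes the place of 2,3-dichlorophenyl on a carbon with a double bond to nitrogen.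

Compound 3 `COc1cc2ncnc(Nc3ccc(F)c(Cl)c3)c2cc1NC(=O)N/N=C/c1ccc(O)cc1` differs from compound 2 in one place hydrogen in place of hydroxy on an aromatic carbon and has hydrogen in place of hydroxy on an aromatic carbon. This carbon is ortho to a large group and meta to a hydroxy group, so 2,4-dihydroxyphenyl becomes 4-hydroxyphenyl. Among the measured compounds shown here, no measured step covers this exact change, so the step between compound 1 and compound 2 is only an indirect guide. It swapped the groups on that ring entirely and stayed within the scatter, which suggests that a smaller edit may also do little, though one step is thin evidence.

No shift beyond the scatter is expected, and the estimated step is a 1.1-fold lower number from compound 2 to compound 3 (0.03 log units; within the scatter) in this assay. For compound 3 the expected value is 30000 nM with an estimated range from 14000 nM to 62000 nM as its limits.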

Compound 3, half-maximal inhibitory concentration: 26300 nM
The estimate for compound 3 lay 1.1-fold (0.06 log units) above the measured number; the measured number falls inside the stated range.
By their numbers in this assay, from the lowest: compounds 1, 3 and 2 (each within the scatter of the next).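

Among these compounds, compound 2 and compound 3 differ only by the hydroxy group on the aromatic carbon ortho to a large group and meta to a hydroxy group, and a 1.2-fold lower number from compound 2 to compound 3 (0.09 log units; within the scatter) in this assay is the first direct test of that single position. On this evidence, removing that hydroxy group, which turns 2,4-dihydroxyphenyl into 4-hydroxyphenyl, produces no change that can be told from the scatter. The step of a 1.0-fold higher number from compound 1 to compound 3 (0.00 log units; within the scatter) adds a second comparison with the 2,3-dichlorophenyl compound, so the two chlorine atoms, the two hydroxy groups and the single hydroxy group all give numbers within the scatter of one another in this read-out, and nothing shown here offers a reason for that.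

The compounds shown leave open whether the remaining hydroxy group of 4-hydroxyphenyl can also go without a change, or whether an amine or a carboxylic acid in its place would move the number beyond the scatter. They also leave open whether a change to the shared core, rather than to this outer ring, would alter the result in this assay at all.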